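The source may hold more compounds than are shown below. What is called first, only, known or untested is meant among the compounds shown, and "the series" means these compounds.

Measured so far:
compound 1 `Cc1cccc2ncnc(O/N=C(\C=C\c3ccccn3)/C=C/c3ccccc3OCc3ccccc3Cl)c12` — in a functional assay on SMMC-7721 cells (Homo sapiens) for inhibition, read by MTT assay, with a stated time of 72 h, tested at 1 uM (on this read-out higher numbers stand for a stronger effect at the one concentration tested and lower numbers for a weaker effect), compound 1 gives 86.8%
compound 2 `Cc1cccc2ncnc(O/N=C(\C=C\c3ccccn3)/C=C/c3ccccc3OCc3ccc(Cl)cc3Cl)c12` — compound 2 gives 90.8%
compound 3 `Clc1ccc(COc2ccccc2/C=C/C(/C=C/c2ccccn2)=N/Oc2ncnc3ccccc23)c(Cl)c1` — compound 3 gives 33.3%

Compound 2 holds the highest of the three numbers. Compound 1 stands within the scatter of it, the step being a number 4 percentage points higher from compound 1 to compound 2 (within the scatter). Compound 3 stands far below it, the step being a number 57.5 percentage points lower from compound 2 to compound 3 (beyond the scatter), and that step concerns the methyl on the shared core, not the benzyl ring.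

Compound 4 `Cc1cccc2ncnc(O/N=C(\C=C\c3ccccn3)/C=C/c3ccccc3OCc3ccc(Cl)cc3)c12` differs from compound 2 by hydrogen in place of chloro on an aromatic carbon. Going by the values given here, only one measured step touches a chloro on the benzyl ring, and it was within the scatter: a number 4 percentage points higher from compound 1 to compound 2 (within the scatter). Where adding a chloro to that ring left the read-out in this assay essentially unchanged, removing one is not expected to produce a step beyond the scatter either; the large step from compound 2 to compound 3 does not bear on this change. The step from compound 2 to compound 4 is therefore expected to be small, a number 5.8 percentage points lower from compound 2 to compound 4 (within the scatter), with no clear direction. Compound 4 is expected to give about 85% in this assay, in the range 70% to 94%.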

Compound 4, a percentage reported as inhibition, at one concentration (the size of the read-out at that concentration, not a potency): 93.4%
Estimate against measurement, compound 4: 8.4 percentage points below; low and high end bracket the measured number.
By their numbers in this assay, from the lowest: compound 3; then compounds 1, 2 and 4 (each within the scatter of the next).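

In this assay the 2,4-dichlorobenzyl and 4-chlorobenzyl groups cannot be told apart, with a number 2.6 percentage points higher from compound 2 to compound 4 (within the scatter), so the chloro ortho to a large group is not needed to keep the read-out at the one concentration tested. Shifting the single chloro gives the same picture, with a number 6.6 percentage points higher from compound 1 to compound 4 (within the scatter), which places the 2-chlorobenzyl, 4-chlorobenzyl and 2,4-dichlorobenzyl groups of compound 1, compound 2 and compound 4 together, so this ring has so far shown no sensitivity to chloro placement.

Still open, as far as these compounds go, is whether a methoxy group, a trifluoromethyl group or an amine on this ring would hold the read-out as the chloro groups do. Also open, from the compounds shown here alone, is whether the 4-chlorobenzyl group depends on the methyl of the shared core as strongly as the 2,4-dichlorobenzyl group does.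

Nothing at hand accounts for why these benzyl groups read alike.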